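A few compounds are considered here, and "the series" means these few. Any claim that something is new, unique, unknown or untested is made for them only; others in the source may bear on it.

Compound 1 `COc1cc(-c2ncnn2-c2ccc([N+](=O)[O-])cc2)cc(OC)c1OC`: > 10000 nM
Compound 2 `COc1cc(-c2ncnn2-c2ccc(N)cc2)cc(OC)c1OC`: > 10000 nM

Both entries come from a functional assay on HL-60 cells (Homo sapiens) for antiproliferative activity, read by MTT assay, with a stated time of 72 h (a higher number here means a weaker inhibitor, a lower number a stronger inhibitor), and both are limits rather than numbers. Compound 2 gives only the limit > 10000 nM, so it has no exact place on the scale. The evidence so far is the limit of > 10000 nM in this assay, at which 2 of the 2 values shown sit.

Compound 3 `COc1cc(-c2ncnn2-c2ccc(Cl)cc2)cc(OC)c1OC` has chloro in place of amino on an aromatic carbon, para to a large group: chloro in place of amino on an aromatic carbon.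

Going by the values given here, the one measured step bearing on this position is a step that the two limits leave unreadable from compound 1 to compound 2, with amino in place of nitro on an aromatic carbon. Among the compounds with values here, it offers no size to carry over, and no measured step covers chloro. In this assay, the expectation is therefore a result at the limit again or a modest move towards stronger inhibition. The expected step is an at least 2.0-fold lower number from compound 2 to compound 3 (0.30 log units; that floor lies within the scatter). Compound 3 is estimated at 5000 nM, with an expected range of 700 nM to 10000 nM.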

Compound 3, half-maximal inhibitory concentration: > 10000 nM
Compound 3 gave a limit, no number; the forecaster's own chance of this, stated with the estimate: 55%; middle value at least 2.0-fold (0.30 log units) away from the limit.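

Compound 1, compound 2 and compound 3 all give only limits in this assay, and the steps among them cannot be read. The compounds shown leave open whether any group at this place on the shared core would give a readable number in this assay.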